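Thiazol-2-yl for thiophen-2-yl: an expected flat step

The source may report more compounds than this note shows. Statements on the series, on what has been measured and on what is new or still open speak of the compounds shown alone.

In a functional assay on A549 cells (Homo sapiens) for cytotoxicity (on this read-out lower numbers stand for an effect already at smaller amounts and higher numbers for an effect only at larger amounts of compound), compound 1 (`COC1=C(C)C(=O)/C(=C(O)/C=C/c2ccc(OC)cc2)C(=O)C1(C)C`) gives 3 ug/mL, and compound 2 (`COC1=C(C)C(=O)/C(=C(O)/C=C/c2cccs2)C(=O)C1(C)C`) gives 4.5 ug/mL. These two numbers lie within the scatter of each other, so compound 2 does not stand apart from compound 1 on the data so far. Compound 3 (`COC1=C(C)C(=O)/C(=C(O)/C=C/c2nccs2)C(=O)C1(C)C`) has not yet been measured. It differs from compound 2 by one change: 1,3-thiazol-2-yl in place of thiophen-2-yl on a double-bonded chain carbon bound to a double-bonded chain carbon. The new group, 1,3-thiazol-2-yl, sits on a double-bonded chain carbon bound to a double-bonded chain carbon, and like thiophen-2-yl it is a five-membered aromatic ring. Going by the values given here, only one measured step bears on this change, a 1.5-fold higher number from compound 1 to compound 2 (0.18 log units; within the scatter), which was made at the same place and stayed within the scatter. Among the compounds with values here, no measured compound in this small set carries 1,3-thiazol-2-yl, so that single step is a thin basis. On that basis, no step beyond the scatter is expected in this assay. The expected change is a 1.1-fold higher number from compound 2 to compound 3 (0.05 log units; within the scatter). For compound 3 the estimated value is 5 ug/mL, with an expected range of 2.5 ug/mL to 10 ug/mL.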

Compound 3, concentration for half-maximal effect: 3.5 ug/mL
For compound 3 the middle estimate is 1.4-fold (0.15 log units) above the measured one, and the stated range covers the measured number.
By their numbers in this assay, from the lowest: compounds 1, 3 and 2 (each within the scatter of the next).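

In this assay the step to the new ring gives a 1.3-fold lower number from compound 2 to compound 3 (0.11 log units; within the scatter) and so stays within the scatter: placing a ring nitrogen in the five-membered aromatic ring, which turns thiophen-2-yl into 1,3-thiazol-2-yl, leaves no readable mark at this position. The comparison with the six-membered aromatic group points the same way, with a 1.2-fold higher number from compound 1 to compound 3 (0.07 log units; within the scatter) and again no step beyond the scatter, so 4-methoxyphenyl, thiophen-2-yl and 1,3-thiazol-2-yl cannot be told apart on a double-bonded chain carbon bound to a double-bonded chain carbon. Nothing measured alongside these numbers offers a reason for this flat picture.

On these data alone, all three compounds carry an aromatic ring at this place, so it remains open whether the read-out would stay as flat with a group of another kind there, such as an amine, a carboxylic acid or a longer saturated carbon chain. The three compounds also share one core, which leaves open whether the same exchange of rings would stay within the scatter on a different core.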